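A few compounds are considered here, and "the series" means these few. Any claim that something is new, unique, unknown or untested is made for them only; others in the source may bear on it.

In a functional assay on MCF7 cells (Homo sapiens) for inhibition (a higher number here means a weaker inhibitor, a lower number a stronger inhibitor), compound 2 `N#CC1CN1C(=O)Nc1ccccc1` gives 4300 nM, the highest of the two numbers in hand. Its nearest neighbour is compound 1 `N#CC1CN1C(=O)Nc1ccc(F)cc1`, which in this assay gives 2700 nM; the step of a 1.6-fold higher number from compound 1 to compound 2 (0.20 log units; within the scatter) lies within the scatter, so the two compounds cannot be told apart. Compound 3 `N#CC1CN1C(=O)Nc1ccc(C(F)(F)F)cc1` has not been measured; it differs from compound 2 by trifluoromethyl in place of hydrogen on an aromatic carbon. Within the data shown here, the only measured step that bears on this change is a 1.6-fold higher number from compound 1 to compound 2 (0.20 log units; within the scatter), in which fluoro on an aromatic carbon was exchanged for hydrogen without an effect beyond the scatter. That single step gives little ground to expect the trifluoromethyl group to move the number far. For compound 3 the expected step in this assay is a 1.4-fold lower number from compound 2 to compound 3 (0.16 log units; within the scatter), none beyond the scatter, leaning slightly lower. Compound 3 is therefore estimated at 3000 nM, with a range of 1000 nM to 9000 nM.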

Compound 3, half-maximal inhibitory concentration: 1300 nM
The estimate for compound 3 lay 2.3-fold (0.36 log units) above the measured number, within the range that was stated.
By their numbers in this assay, from the lowest: compound 3; then compounds 1 and 2 (each within the scatter of the next).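

Among these compounds, the aromatic carbon para to a group of 8 heavy atoms does respond to what it carries: in this assay trifluoromethyl in place of hydrogen gives a 3.3-fold lower number from compound 2 to compound 3 (0.52 log units; beyond the scatter) and is one of the first steps in this set to clear the scatter. Trifluoromethyl also separates from fluoro, with a 2.1-fold lower number from compound 1 to compound 3 (0.32 log units; beyond the scatter) as the result, whereas the step between fluoro and hydrogen stayed within the scatter. No measurement shown here accounts for these modest steps.

Going by these compounds, only hydrogen, fluoro and trifluoromethyl appear at this carbon, so it remains open how an amine, a methoxy group or a carboxylic acid would behave there. On these data alone, it also remains open whether trifluoromethyl would give a similar step at another carbon of the ring.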